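Fluoro on a phenyl ring at the assay limit

This account rests on a few compounds, and the source may have more. Where it says the series, first, only, none or still open, it means among the compounds named here.

In an ADME assay on BHK-21 cells (Mesocricetus auratus) for cytotoxicity, read by MTT assay, with a stated time of 120 h (on this read-out lower numbers stand for higher toxicity in this test and higher numbers for lower toxicity in this test), compound 3 (`O=C1C2=C(SCCS2)C(=O)N1CCCCN1CCN(c2ccccc2)CC1`) gives > 100000 nM as a limit of the assay, not a number. Compound 1 (`O=C1C2=C(SCCS2)C(=O)N1CC(O)CN1CCN(c2ccc(F)cc2)CC1`) gives > 100000 nM as a limit too. Compound 2 (`COc1ccccc1N1CCN(CC(O)CN2C(=O)C3=C(SCCS3)C2=O)CC1`) gives > 100000 nM as a limit as well. Every result so far stands at the limit of > 100000 nM in this assay, at which 3 of the 3 values shown sit, without exception.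

Compound 4 (`O=C1C2=C(SCCS2)C(=O)N1CCCCN1CCN(c2ccc(F)cc2)CC1`) differs from compound 3 by fluoro in place of hydrogen on an aromatic carbon, para to a large group (fluoro in place of hydrogen on an aromatic carbon). Among the compounds with values here, the only measured step is a step that the two limits leave unreadable from compound 1 to compound 2 with 2-methoxyphenyl in place of 4-fluorophenyl on an amine nitrogen in a ring, so it offers no size to carry over. Compound 1 carries the 4-fluorophenyl group and gives > 100000 nM as a limit, and the expectation rests on this. No step beyond the usual scatter is therefore expected in this assay in either direction. The expected size is a number no higher from compound 3 to compound 4 (the limit leaves the size open) in this estimate. For compound 4 the estimated value is 100000 nM within an expected range of 50000 nM to 200000 nM and the assay will most likely report only a limit again.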

Compound 4, half-maximal cytotoxic concentration: > 100000 nM
Compound 4: no number, only a limit; the forecaster's own chance of this, stated with the estimate: 85%; the middle value sits exactly at the limit.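

Compound 3 and compound 4 each give only a limit and not a number, so no step can be read between them: the limit of > 100000 nM in this assay, at which 4 of the 4 values shown sit.

Whether phenyl to 4-fluorophenyl, or any other difference among these compounds, changes the result in this assay stays open.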